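The source may report more compounds than this note shows. Statements on the series, on what has been measured and on what is new or still open speak of the compounds shown alone.

Working notes on the alkoxy series sharing the core of compound 1.

Compound 3, `CCCCCCCOc1ccc2nncn2n1`, gives 42.4 mg/kg in a functional assay on the whole organism with Mus musculus as the target; a lower number here means that less compound is needed, a higher number that more compound is needed for the effect. Among the compounds with values here, this is the highest of the three numbers so far, but its steps to both neighbours are within the scatter. Compound 1, `CCCCCOc1ccc2nncn2n1`, gives 39.4 mg/kg in this assay, and compound 2, `CCCCCCOc1ccc2nncn2n1`, gives 32.9 mg/kg. The steps along the chain were a 1.2-fold lower number from compound 1 to compound 2 (0.08 log units; within the scatter), a 1.1-fold higher number from compound 1 to compound 3 (0.03 log units; within the scatter) and a 1.3-fold higher number from compound 2 to compound 3 (0.11 log units; within the scatter): three chain extensions, none beyond the scatter.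

Compound 4, `CCCCCCCCOc1ccc2nncn2n1`, carries the next such change: methyl in place of hydrogen on a saturated chain carbon, seven bonds along the chain from an oxygen on an aromatic ring. All three measured steps bear on it, each being a chain extension of the same kind, and each stayed within the scatter. A step of like size is therefore expected in this assay, with no direction to be read from the series.

Compound 4 is expected to give 40 mg/kg in this assay, within a range of 24 mg/kg to 68 mg/kg. That estimate means a step of a 1.1-fold lower number from compound 3 to compound 4 (0.03 log units; within the scatter).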

Compound 4, dose for half-maximal effect: > 100 mg/kg
Compound 4: only a limit was reported (the forecaster's own chance of this, stated with the estimate: 5%); middle value at least 2.5-fold (0.39 log units) from the limit.
By their numbers in this assay, from the lowest: compounds 2, 1 and 3 (each within the scatter of the next). At a limit, above all of these: compound 4.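

Methyl in place of hydrogen at seven bonds along the chain from an oxygen on an aromatic ring is the first chain extension in this series to go beyond the scatter in this assay: the step is an at least 2.3-fold higher number from compound 3 to compound 4 (0.37 log units; beyond the scatter), and the longer differences agree, with an at least 3.0-fold higher number from compound 2 to compound 4 (0.48 log units; beyond the scatter) and an at least 2.5-fold higher number from compound 1 to compound 4 (0.40 log units; beyond the scatter). The same methyl change therefore does not carry over unchanged from one place on the chain to another: the same change on two cores in this assay, a 1.2-fold lower number (0.08 log units; within the scatter) from compound 1 to compound 2 and an at least 2.3-fold higher number (0.37 log units; beyond the scatter) from compound 3 to compound 4, at least 2.8-fold (0.45 log units) apart, beyond the scatter of two such steps Compound 4 stands only as a limit, > 100 mg/kg: the limit of > 100 mg/kg in this assay, at which 1 of the 4 values shown sits.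

How far past this limit compound 4 lies remains open, and the compounds shown give no cause for the step. Also open, going by these compounds, is whether a longer chain, or an amine in place of the entering methyl, would keep the number of this assay as high as in compound 4.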